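This account rests on a few compounds, and the source may have more. Where it says the series, first, only, none or still open, it means among the compounds named here.

Three compounds have been measured in an ADME assay on PC-3 cells (Homo sapiens) for cytotoxicity, read by sulforhodamine B assay, with a stated time of 48 h, tested at 10 uM; a lower number here means less inhibition, a higher number more inhibition at the concentration tested (going by the name of the read-out):

compound 1 `CCCCCCCc1cn(C(c2ccccc2)c2cc3cc(Br)ccc3nc2OC)nn1` gives 4.42%
compound 2 `CCCCCCc1cn(C(c2ccccc2)c2cc3cc(Br)ccc3nc2OC)nn1` gives 2.32%
compound 3 `COc1nc2ccc(Br)cc2cc1C(c1ccccc1)n1cc(-c2ccccc2)nn1` gives 5.97%

Compound 2 sits at the low end of these three numbers, though none of the three is separated from another beyond the scatter: the step from compound 1 to compound 2 is a number 2.1 percentage points lower from compound 1 to compound 2 (within the scatter), and from compound 2 to compound 3 it is a number 3.7 percentage points higher from compound 2 to compound 3 (within the scatter). Compound 4 `COc1nc2ccc(Br)cc2cc1C(c1ccccc1)n1cc(-c2ccc(OC(F)(F)F)cc2)nn1` differs from compound 2 in one place: 4-(trifluoromethoxy)phenyl in place of hexyl on an aromatic carbon. For the measured compounds named here, the steps that bear on this change are those that exchange the chain on the same aromatic carbon for a phenyl, namely a number 3.7 percentage points higher from compound 2 to compound 3 (within the scatter) and a number 1.6 percentage points higher from compound 1 to compound 3 (within the scatter), both within the scatter. On that basis no step beyond the scatter is expected in this assay; the expected step is a number 2.7 percentage points higher from compound 2 to compound 4 (within the scatter). Compound 4 is therefore estimated to give 5%, with a likely range from 0% to 15%.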

Compound 4, a percentage reported as inhibition, at one concentration (the size of the read-out at that concentration, not a potency): 21.6%
Compound 4: the middle estimate sits 16.6 percentage points below what was measured, outside the stated range (above it).
By their numbers in this assay, from the lowest: compounds 2, 1 and 3 (each within the scatter of the next); then compound 4.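

In this assay the aromatic carbon of the five-membered ring proves able to carry a change that moves the number beyond the scatter: adding trifluoromethoxy in place of hydrogen on the phenyl gives a number 15.6 percentage points higher from compound 3 to compound 4 (beyond the scatter) and so separates two compounds that share everything else. The same group's phenyl also stands clear of both chains, with a number 19.3 percentage points higher from compound 2 to compound 4 (beyond the scatter) against hexyl and a number 17.2 percentage points higher from compound 1 to compound 4 (beyond the scatter) against heptyl, whereas plain phenyl had stayed within the scatter of them. Nothing measured here accounts for this rise in inhibition.

Whether the rise belongs to trifluoromethoxy in particular stays open, since no other group, such as methoxy, chlorine or an amine, is shown on that phenyl. Going by these compounds, whether it would carry over to a core without the bromine also stays open.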